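The source may report more compounds than this note shows. Statements on the series, on what has been measured and on what is new or still open speak of the compounds shown alone.

Measured so far: compound 1 `O=C(Nc1cc(F)cc2cccnc12)c1cnccn1`, 670 nM; compound 2 `O=C(Nc1cc(Cl)cc2cccnc12)c1cnccn1`, 2700 nM; compound 3 `O=C(Nc1cc(F)cc2cccnc12)c1ncccn1`, 5300 nM.

All three values come from a functional assay on PANC-1 cells (Homo sapiens) for inhibition, read by MTT assay, with a stated time of 72 h; on this read-out lower numbers stand for stronger inhibition and higher numbers for weaker inhibition. Compound 2 differs from compound 1 by chloro in place of fluoro on an aromatic carbon, and that change gives a 4.0-fold higher number from compound 1 to compound 2 (0.61 log units; beyond the scatter). Compound 3 differs from compound 1 in the core: pyrimidin-2-yl in place of pyrazin-2-yl on a carbonyl carbon, giving a 7.9-fold higher number from compound 1 to compound 3 (0.90 log units; beyond the scatter). Compound 2 and compound 3 sit within the scatter of each other in this assay. Compound 4 `O=C(Nc1cc(Cl)cc2cccnc12)c1ncccn1` has not been measured; it differs from compound 3 by chloro in place of fluoro on an aromatic carbon, the same change at the same place as from compound 1 to compound 2. The expected step in this assay is a 3.4-fold higher number from compound 3 to compound 4 (0.53 log units; beyond the scatter), which rests on the earlier step of a 4.0-fold higher number from compound 1 to compound 2 (0.61 log units; beyond the scatter) made by the same change. Compound 4 is therefore estimated at 18000 nM, expected to lie between 7000 nM and 45000 nM.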

Compound 4, half-maximal inhibitory concentration: 4670 nM
Compound 4: middle estimate off by 3.9-fold (0.59 log units), on the high side; measured number below the stated range.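

In this assay, chloro in place of fluoro gives a 1.1-fold lower number from compound 3 to compound 4 (0.05 log units; within the scatter), so the step seen on the core of compound 1 does not carry over to the core of compound 3: the same change on two cores in this assay, a 4.0-fold higher number (0.61 log units; beyond the scatter) from compound 1 to compound 2 and a 1.1-fold lower number (0.05 log units; within the scatter) from compound 3 to compound 4, 4.6-fold (0.66 log units) apart, beyond the scatter of two such steps. Likewise, pyrimidin-2-yl in place of pyrazin-2-yl gives a 1.7-fold higher number from compound 2 to compound 4 (0.24 log units; within the scatter), so the size of this step depends on which halogen is present: the same change on two cores in this assay, a 7.9-fold higher number (0.90 log units; beyond the scatter) from compound 1 to compound 3 and a 1.7-fold higher number (0.24 log units; within the scatter) from compound 2 to compound 4, 4.6-fold (0.66 log units) apart, beyond the scatter of two such steps. These four compounds show that the two changes do not simply add, but they do not show why, and one pair per change cannot predict the result on any further core.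

Still open, going by these compounds, is how an amine or a methoxy group would behave in place of the fluoro or chloro. Also open, on these data alone, is whether a pyridin-2-yl group on the carbonyl carbon would follow either pattern.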